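Replacing the Difluoropyridine with an Aminomethylpyridine

The source may report more compounds than this note shows. Statements on the series, on what has been measured and on what is new or still open speak of the compounds shown alone.

Measured so far:
- compound 1, `O=C(O)Cc1sc(C(c2ccc(F)cc2)c2ccc(F)cc2)nc1-c1ccccc1`: 240 nM in an in vitro functional assay on HEK285-7 cells for antagonist activity at prostaglandin D2 receptor 2 (Homo sapiens), read by BRET and beta-arrestin recruitment; on this read-out higher numbers stand for weaker inhibition and lower numbers for stronger inhibition
- compound 2, `O=C(O)Cc1sc(C(c2ccc(F)cc2)c2ccc(F)cc2)nc1-c1cc(F)nc(F)c1`: 110 nM in this assay

Compound 2 has the lower of the two numbers; the step of a 2.2-fold lower number from compound 1 to compound 2 (0.34 log units; beyond the scatter) is modest but beyond the scatter, so compound 2 counts as the stronger inhibitor of this pair. Compound 3, `Cc1cc(-c2nc(C(c3ccc(F)cc3)c3ccc(F)cc3)sc2CC(=O)O)cnc1N`, has not yet been measured. It differs from compound 2 in one place: 6-amino-5-methylpyridin-3-yl in place of 2,6-difluoropyridin-4-yl on an aromatic carbon. Within the data shown here, the single measured step also exchanged the ring at this position, and it shifted the number only modestly. That step gives no guide to which way a ring carrying an amino group and a methyl group will move the number, so no change beyond the scatter is expected; the estimated step is a 1.4-fold higher number from compound 2 to compound 3 (0.13 log units; within the scatter). Compound 3 is therefore expected to give about 150 nM in this assay, most likely between 50 nM and 450 nM.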

Compound 3, half-maximal inhibitory concentration: > 100000 nM
Compound 3 gave a limit, no number; the forecaster's own chance of this, stated with the estimate: 5%; middle value at least 660-fold (2.82 log units) from the limit.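

Compound 3 gives a limit of the assay and not a number: the limit of > 100000 nM in this assay, at which 1 of the 3 values shown sits. The earlier ring exchange gave only a 2.2-fold lower number from compound 1 to compound 2 (0.34 log units; beyond the scatter), whereas 6-amino-5-methylpyridin-3-yl gives an at least 900-fold higher number from compound 2 to compound 3 (2.95 log units; beyond the scatter), and, set against the phenyl ring, an at least 410-fold higher number from compound 1 to compound 3 (2.61 log units; beyond the scatter). The leaving and entering pyridine groups hold the same count of heavy atoms, and each is a six-membered aromatic ring with 1 hetero atom, so this position clearly does not accept every such ring, and a single ring exchange here can carry a very large step.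

This change removes both fluorines and adds an amino group and a methyl group at once, so the compounds shown cannot assign the step to any one of these. A pyridine ring bearing only the amino group, or only the methyl group, would begin to separate them.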